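Compound 1 loses its (3,4-dichlorophenyl)amino group

The compounds below may be only part of what the source reports. "The series", "measured", "known", "first", "only" and "open" are said of these compounds alone.

Among the compounds with values here, in a functional assay on 786-0 cells (Homo sapiens) for inhibition, read by sulforhodamine B assay, with a stated time of 48 h (a higher number here means a weaker inhibitor of growth, a lower number a stronger inhibitor of growth), compound 1 (`COc1cc(-c2nn(-c3cccc(NC(=O)Nc4ccc(Cl)c(Cl)c4)c3)cc2-c2ccncc2)ccc1Cl`) gives 4470 nM, the only exact number so far. Compound 2 (`O=C(Nc1cccc(-n2cc(-c3ccncc3)c(-c3ccc(Cl)c(O)c3)n2)c1)Nc1ccc(Cl)c(Cl)c1`) is reported only as a limit of the assay, > 32500 nM.

Compound 3 (`COc1cc(-c2nn(-c3cccc(NC(=O)c4ccccc4)c3)cc2-c2ccncc2)ccc1Cl`) differs from compound 1 at another place: phenyl in place of (3,4-dichlorophenyl)amino on a carbonyl carbon. Within the data shown here, no measured step touches this place. Among the measured compounds shown here, the only guide is an at least 7.2-fold higher number from compound 1 to compound 2 (0.86 log units; beyond the scatter), a step beyond the scatter that comes with hydrogen in place of methyl on an oxygen on an aromatic ring. It shows that one change can move the number a long way here, so a move in the same direction, towards weaker inhibition of growth, is expected. The expected size is a 3.1-fold higher number from compound 1 to compound 3 (0.50 log units; beyond the scatter). For compound 3 the estimated value is 14000 nM, with a range of 5000 nM to 32500 nM.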

Compound 3, concentration for total growth inhibition: > 100000 nM
Compound 3 was reported as a limit; the forecaster's own chance of this, stated with the estimate: 35%; middle value at least 7.1-fold (0.85 log units) away from the limit.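

In this assay compound 3 gives > 100000 nM, which is a limit and not a number. Within the data shown here, the place on the carbonyl carbon, which no earlier step touched, therefore matters as well, since phenyl in place of (3,4-dichlorophenyl)amino gives an at least 22-fold higher number from compound 1 to compound 3 (1.34 log units; beyond the scatter), so growth inhibition here depends on this group as well as on the methyl on the oxygen. The true size of this step stays unknown because compound 3 stands at a limit: the limit of > 100000 nM in this assay, at which 1 of the 3 values shown sits.

The change removes the amino nitrogen and both chlorine atoms at once, so the compounds shown cannot say which of these counts. A plain phenylamino group or a 3,4-dichlorophenyl group set directly on the carbonyl carbon would tell the two apart.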